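The source may report more compounds than this note shows. Statements on the series, on what has been measured and on what is new or still open speak of the compounds shown alone.

Three analogues built on one shared core have been tested in a functional assay on PC-3 cells (Homo sapiens) for cytotoxicity, read by MTT assay, with a stated time of 72 h; a higher number here means a weaker inhibitor, a lower number a stronger inhibitor. Compound 1 `Cc1ccc(-n2nc(C(=O)Nc3ccc(Oc4ncnc5[nH]ccc45)cc3)c(C)cc2=O)cc1` gives 9610 nM in this assay. Compound 2 `Cc1cc(=O)n(-c2ccc(F)cc2)nc1C(=O)Nc1ccc(Oc2ncnc3[nH]ccc23)c(F)c1` gives 17300 nM in this assay. Compound 3 `Cc1cc(=O)n(-c2cccc(F)c2)nc1C(=O)Nc1ccc(Oc2ncnc3[nH]ccc23)c(F)c1` gives 6680 nM in this assay. Among these three numbers compound 3 stands lowest, with compound 1 close to it, within the scatter, and compound 2 further away, beyond it. Among the compounds with values here, the only step that joins two measured compounds in one place is a 2.6-fold lower number from compound 2 to compound 3 (0.41 log units; beyond the scatter), a modest change.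

Compound 4 `Cc1ccc(-n2nc(C(=O)Nc3ccc(Oc4ncnc5[nH]ccc45)c(F)c3)c(C)cc2=O)cc1` has not yet been measured. It differs from compound 3 in that (4-methylphenyl in place of 3-fluorophenyl on an aromatic nitrogen). The step from compound 2 to compound 3 bears on this only in part, since there one fluorophenyl was exchanged for another, whereas here a methylphenyl enters. Compound 1 carries the same 4-methylphenyl and gives 9610 nM, which sits close to compound 3. On that basis compound 4 is expected to stay near compound 3 in this assay, and the expected step is a 1.5-fold higher number from compound 3 to compound 4 (0.18 log units; within the scatter), nothing that should clearly exceed the scatter. The estimate for compound 4 is 10000 nM, with a range from 5000 nM to 22000 nM.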

Compound 4, half-maximal inhibitory concentration: 20400 nM
For compound 4 the middle estimate is 2.0-fold (0.31 log units) below the measured one; measured number inside the range.
By their numbers in this assay, from the lowest: compounds 3, 1, 2 and 4 (each within the scatter of the next, the first and the last beyond it).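

The exchange on the aromatic nitrogen matters more than compound 1 alone suggested: in this assay, 4-methylphenyl in place of 3-fluorophenyl gives a 3.1-fold higher number from compound 3 to compound 4 (0.48 log units; beyond the scatter). Among the compounds with fluoro on the aromatic carbon of the shared core, 4-methylphenyl and 4-fluorophenyl cannot be told apart, with a 1.2-fold higher number from compound 2 to compound 4 (0.07 log units; within the scatter), so compound 3 with its 3-fluorophenyl stands apart from compound 2 and compound 4 alike. The series also gains its first reading of fluoro in place of hydrogen on that aromatic carbon, a 2.1-fold higher number from compound 1 to compound 4 (0.33 log units; beyond the scatter), although this rests on a single pair carrying 4-methylphenyl and cannot be extended to the other aryl groups.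

Nothing available explains why these numbers differ, and the measurements offer no account of the effect of either change. Still open, on these data alone, is whether the 3-fluorophenyl result depends on the fluoro on the aromatic carbon of the core, and whether a methoxy group or an amine on the phenyl ring would follow compound 3 or compound 4.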